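The compounds below may be only part of what the source reports. "The series", "measured", "known", "first", "only" and "open" are said of these compounds alone.

Among the measured compounds shown here, compound 2 `COc1ccc(/C=N/N(Cc2ccccc2)Cc2ccccc2)cc1` gives 220 nM in an assay on liver (Sus scrofa) for inhibition of glucose-6-phosphatase catalytic subunit 1 (Homo sapiens), using microsomes (a higher number here means a weaker inhibitor, a lower number a stronger inhibitor), the lowest of the two numbers measured so far. For the measured compounds named here, compound 3 `CN(C)c1ccc(/C=N/N(Cc2ccccc2)Cc2ccccc2)cc1` gives 100000 nM, and the step of a 450-fold higher number from compound 2 to compound 3 (2.66 log units; beyond the scatter) is the only measured step available. Compound 1 `COc1ccc2c(c1)CCC/C2=N\N(Cc1ccccc1)Cc1ccccc1` reaches only the limit of this assay, > 50000 nM (the limit of > 50000 nM in this assay, at which 1 of the 3 values shown sits). Compound 4 `Clc1ccc(/C=N/N(Cc2ccccc2)Cc2ccccc2)cc1Cl` differs from compound 2 by 3,4-dichlorophenyl in place of 4-methoxyphenyl on a carbon with a double bond to nitrogen. This change is not the same as the measured one, but that measured step shows that exchanging the group on this ring can cost a great deal of potency. Compound 4 is therefore expected to come out weaker, with a 9.1-fold higher number from compound 2 to compound 4 (0.96 log units; beyond the scatter). The estimate for compound 4 in this assay is 2000 nM, within a range from 300 nM to 20000 nM.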

Compound 4, half-maximal inhibitory concentration: 2000 nM
Compound 4: middle estimate and measured number agree at the digits printed; low and high end bracket the measured number.
By their numbers in this assay, from the lowest: compound 2; then compound 4; then compound 3.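

In this assay, exchanging the ring on this carbon with a double bond to nitrogen need not cost nearly everything: this change gives a 9.1-fold higher number from compound 2 to compound 4 (0.96 log units; beyond the scatter), a real loss but smaller than a 450-fold higher number from compound 2 to compound 3 (2.66 log units; beyond the scatter). The entering 3,4-dichlorophenyl carries no hydrogen-bond acceptor, so the acceptor counted on 4-methoxyphenyl is not required for the inhibition seen with compound 4. Nothing measured here accounts for the size of this step. Still open, from the compounds shown here alone, is whether a ring with a single chlorine, or with a fluorine or nitrile instead, would keep more of the potency of compound 2.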